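The source may report more compounds than this note shows. Statements on the series, on what has been measured and on what is new or still open speak of the compounds shown alone.

Measured in an in vivo ADME assay on the whole organism for pharmacokinetics, with Canis familiaris (Canis lupus familiaris) as the target, using cassette dosing, at a dose of 0.25 mg/kg by the intravenous route; on this read-out lower numbers stand for slow clearance and higher numbers for fast clearance:
- compound 1 `CCCS(=O)(=O)N1CCC(CNC(=O)c2ccc(Cl)cc2Cl)(C2CCCCC2OC(C)=O)CC1`: > 15 mL/min/kg (a limit)
- compound 2 `CCCS(=O)(=O)N1CCC(CNC(=O)c2ccc(Cl)cc2Cl)(CC2CC2)CC1`: > 15 mL/min/kg (a limit)

Compound 2 stands at > 15 mL/min/kg, which is a limit and not a number. Going by the values given here, neither compound has a numeric value so far, with the limit of > 15 mL/min/kg in this assay, at which 2 of the 2 values shown sit, as the only summary available. Compound 3 `CCS(=O)(=O)N1CCC(CNC(=O)c2ccc(Cl)cc2Cl)(CC2CC2)CC1` differs from compound 2 as follows: hydrogen in place of methyl on a saturated chain carbon, two bonds along the chain from a sulfonyl sulfur, that is, propylsulfonyl to ethylsulfonyl. Among the compounds with values here, the only measured step, a step that the two limits leave unreadable from compound 1 to compound 2, lies elsewhere on the molecule and gives no size to carry over, so no step beyond the scatter is expected in this assay, and no direction is favoured. The expected step is a step that the limit leaves unreadable from compound 2 to compound 3. Compound 3 is estimated at 20 mL/min/kg, with an expected range of 10 mL/min/kg to 40 mL/min/kg.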

Compound 3, clearance: 0.84 mL/min/kg
Beside the measured number, compound 3's estimate is 24-fold (1.38 log units) above it; the whole stated range lies above it.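

In this assay, going by these compounds alone, replacing propylsulfonyl with ethylsulfonyl gives an at least 17-fold lower number from compound 2 to compound 3 (1.25 log units; beyond the scatter), the first readable step, and it shows that this saturated chain carbon, untouched by the earlier pair, can strongly shift clearance. Compound 2 holds a limit and not a number, so the step has only a lower bound: the limit of > 15 mL/min/kg in this assay, at which 2 of the 3 values shown sit. The step from compound 1 to compound 2 cannot be read.

Going by these compounds, whether methylsulfonyl or butylsulfonyl would follow the same direction stays open. Also open, on these data alone, is whether ethylsulfonyl gives a similar step with the 2-acetoxycyclohexyl group in place of cyclopropylmethyl.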